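Prenyl side-chain variants of a dihydroxystilbene series

The compounds below may be only part of what the source reports. "The series", "measured", "known", "first", "only" and "open" are said of these compounds alone.

Three members have been read in a physicochemical assay for lipophilicity, read by HPLC, measured as octanol-water partition; on this read-out lower numbers stand for lower lipophilicity and higher numbers for higher lipophilicity. Compound 1 `CC1(C)C=Cc2c(O)cc(/C=C/c3ccc(O)cc3)cc2O1` gives 3.34, the highest of the three. Compound 3 `Oc1ccc(/C=C/c2cccc(O)c2)cc1` gives 2.08, the lowest. Compound 2 `CC(C)(O)C(O)Cc1c(O)cc(/C=C/c2ccccc2)cc1O` gives 2.59, second highest of the three numbers, sitting beyond the scatter from both neighbours: compound 3 lies lower, compound 1 higher.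

Compound 4 `CC(C)=CCc1c(O)cc(/C=C/c2ccccc2)cc1O` is not yet measured. Its structure differs from compound 2 as follows: 2-methylprop-1-en-1-yl in place of 1,2-dihydroxy-2-methylpropyl on a saturated chain carbon bound to an aromatic carbon. The leaving group carries hydrogen-bond donors and acceptors; the entering group carries none.

For compound 4 a marked rise in this assay is expected, a number 1.71 log units higher from compound 2 to compound 4 (beyond the scatter), well beyond the scatter. The estimate for compound 4 is 4.3, with a plausible range from 3.7 to 4.9.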

Compound 4, partition coefficient: 3.46
Compound 4: the middle estimate sits 0.84 log units above what was measured; measured number below the stated range.
By their numbers in this assay, from the lowest: compound 3; then compound 2; then compounds 1 and 4 (each within the scatter of the next).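

In this assay, going by these compounds alone, the change from 2,3-dihydroxy-3-methylbutyl to 3-methylbut-2-en-1-yl reads as a number 0.87 log units higher from compound 2 to compound 4 (beyond the scatter) and provides the only single-place step, showing that this chain position responds to a change of side chain. That step comes from one pair on one core, and nothing measured here accounts for its size.

Open, from the compounds shown here alone, is how a carboxylic acid or an amine on the same chain would read. Also open, going by these compounds, is how a longer chain, such as 3,7-dimethylocta-2,6-dien-1-yl, would compare with 3-methylbut-2-en-1-yl.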